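Ethynyl for Chloro on the Fused Ring of Compound 3

The source may report more compounds than this note shows. Statements on the series, on what has been measured and on what is new or still open speak of the compounds shown alone.

Compound 1 `CC(C)(C)c1cc(NC(=O)Nc2ccc(-c3cc4ccccc4s3)cc2)no1` gives only a limit in a functional assay on MV4-11 cells (Homo sapiens) for cytotoxicity, read by MTT assay, with a stated time of 72 h (a lower number here means a stronger inhibitor, a higher number a weaker inhibitor), namely > 900 nM.
Compound 2 `CC(C)(C)c1cc(NC(=O)Nc2ccc(-c3nc4ccccc4o3)cc2)no1` gives 82.6 nM in this assay.
Compound 3 `CC(C)(C)c1cc(NC(=O)Nc2ccc(-c3cn4ccc(Cl)cc4n3)cc2)no1` gives 5.91 nM in this assay.

Of the two numbers measured in this assay, compound 3 holds the lowest; its nearest neighbour is compound 2, whose higher number lies beyond the usual scatter. The limit for compound 1 stands apart as a limit only (the limit of > 900 nM in this assay, at which 1 of the 3 values shown sits).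

For the measured compounds named here, the one measured step that changes the fused ring system, an at least 10-fold lower number from compound 1 to compound 2 (1.03 log units; beyond the scatter), swaps one bicycle for another and is large. Compound 4 `C#Cc1ccn2cc(-c3ccc(NC(=O)Nc4cc(C(C)(C)C)on4)cc3)nc2c1` keeps the core of compound 3 and changes only a substituent on its fused ring: ethynyl in place of chloro on an aromatic carbon. Going by the values given here, no measured pair exchanges one small substituent for another on that ring, so the step from compound 1 to compound 2 does not bear directly on it, and no evidence for the size or direction of this change exists among the measured compounds.

Compound 4 is therefore expected to stay close to compound 3, with a 1.2-fold higher number from compound 3 to compound 4 (0.07 log units; within the scatter) expected to lie within the scatter. The estimate for compound 4 in this assay is 7 nM, within a range from 2.5 nM to 20 nM.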

Compound 4, half-maximal inhibitory concentration: 3.46 nM
Compound 4: middle estimate off by 2.0-fold (0.31 log units), on the high side, within the range that was stated.
By their numbers in this assay, from the lowest: compounds 4 and 3 (each within the scatter of the next); then compound 2. At a limit, above all of these: compound 1.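

In this assay the exchange of chloro for ethynyl gives a small step (a 1.7-fold lower number from compound 3 to compound 4 (0.23 log units; within the scatter)), so on this aromatic carbon, opposite the ring nitrogen, the two groups cannot be told apart, and the triple bond of ethynyl is accepted here as well as the chlorine. The other measured step (an at least 10-fold lower number from compound 1 to compound 2 (1.03 log units; beyond the scatter)) swaps one whole bicycle for another, which says nothing about a substituent on the fused ring, so the pair of compound 3 and compound 4 is the only one shown that speaks to this position. Nothing measured among these compounds gives a reason for the two groups behaving alike at this carbon.

The compounds shown leave open whether this position needs a substituent at all, since plain hydrogen on this carbon does not appear among them, and whether the same freedom extends to an amine, a carboxylic acid or a longer chain such as propynyl. They also leave open whether ethynyl and chloro would match in the same way on the other carbons of the fused ring.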